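Trimming an Ethyl to Methyl: Expected Permeability

The source may hold more compounds than are shown below. What is called first, only, known or untested is meant among the compounds shown, and "the series" means these compounds.

Compound 1 `CCc1c(C)[nH]c2cc(OC)c(F)cc2c1=O` gives 19.1 10^-6 cm/s in an ADME assay for permeability, using PAMPA, at pH 7.4; a higher number here means that the compound crosses the layer faster, a lower number that the compound crosses the layer more slowly.
Compound 2 `CCc1c(C)[nH]c2cc(OC)c(Cl)cc2c1=O` gives 57.3 10^-6 cm/s.
Compound 3 `CCc1c(C)[nH]c2cc(OC)c(Br)cc2c1=O` gives 75.1 10^-6 cm/s.

Compound 2 stands second highest of the three numbers as they stand: the step of a 3.0-fold higher number from compound 1 to compound 2 (0.48 log units; beyond the scatter) lies beyond the scatter, while a 1.3-fold higher number from compound 2 to compound 3 (0.12 log units; within the scatter) lies within it, so compounds 2 and 3 cannot be told apart. Compound 4 `COc1cc2[nH]c(C)c(C)c(=O)c2cc1Cl` differs from compound 2 by hydrogen in place of methyl on a saturated chain carbon bound to an aromatic carbon. For the measured compounds named here, none of the measured steps touches this kind of change; all three concern one halogen in place of another on an aromatic carbon, and even the largest, a 3.9-fold higher number from compound 1 to compound 3 (0.59 log units; beyond the scatter), is only modest. With only one carbon leaving the chain, the expected step of a 1.3-fold lower number from compound 2 to compound 4 (0.10 log units; within the scatter) is small, most likely within the scatter, if anything slightly lower. Compound 4 is therefore estimated at 45 10^-6 cm/s, within 22 10^-6 cm/s to 80 10^-6 cm/s.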

Compound 4, apparent permeability: 59.2 10^-6 cm/s
Beside the measured number, compound 4's estimate is 1.3-fold (0.12 log units) below it; measured number inside the range.
By their numbers in this assay, from the lowest: compound 1; then compounds 2, 4 and 3 (each within the scatter of the next).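

Here the chain changes for the first time, since the earlier steps all swapped one halogen for another. Going from ethyl to methyl gives a 1.0-fold higher number from compound 2 to compound 4 (0.01 log units; within the scatter) in this assay and so, with the chloro kept, this one carbon makes no readable difference at this position. No measurement shown explains this result.

The compounds shown leave open whether a longer chain, or a chain carrying an amine, would also leave the number in place. They also leave open whether the same trimming holds with fluoro or bromo on the shared core.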